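Moving the fluorine on the pendant phenyl ring

The source may report more compounds than this note shows. Statements on the series, on what has been measured and on what is new or still open speak of the compounds shown alone.

Measured compounds:
- compound 1, `FC1(Cc2ccccc2)CCN(CCCc2c[nH]c3ccc(-n4cnnc4)cc23)CC1`: 15 nM
- compound 2, `Fc1cccc(CCC2(F)CCN(CCCc3c[nH]c4ccc(-n5cnnc5)cc34)CC2)c1`: 22 nM

Both were tested in an assay on CHO cells for displacement of a labelled ligand from 5-hydroxytryptamine receptor 1B (Homo sapiens); a higher number here means a weaker inhibitor, a lower number a stronger inhibitor. On these two numbers compound 2 has the higher number of the pair, but the only gap separating it from compound 1 is a 1.5-fold higher number from compound 1 to compound 2 (0.17 log units; within the scatter), so the two are not distinguishable.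

Compound 3, `Fc1ccc(CCC2(F)CCN(CCCc3c[nH]c4ccc(-n5cnnc5)cc34)CC2)cc1`, has not been measured. Its difference from compound 2 is 4-fluorophenyl in place of 3-fluorophenyl on a saturated chain carbon, two bonds along the chain from a saturated ring carbon; the fluorine simply sits at a different position of the same ring, and nothing else in the molecule moves.

For the measured compounds named here, the only step on record, a 1.5-fold higher number from compound 1 to compound 2 (0.17 log units; within the scatter), added a fluorine-bearing ring in place of a plain phenyl and left the number essentially where it was. Going by the values given here, no measured pair shows what shifting the fluorine within the ring does, so there is no direct precedent. Given that the one related change stayed inside the scatter, the step of no change at the digits printed from compound 2 to compound 3 (within the scatter) is expected to be small as well, with no clear direction. Compound 3 is therefore estimated at 22 nM in this assay, within a range of 8 nM to 60 nM.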

Compound 3, half-maximal inhibitory concentration: 25 nM
The estimate for compound 3 lay 1.1-fold (0.06 log units) below the measured number; low and high end bracket the measured number.
By their numbers in this assay, from the lowest: compounds 1, 2 and 3 (each within the scatter of the next).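

In this assay, for the compounds shown here, this is the first direct reading of where the fluorine sits on the pendant ring: 4-fluorophenyl in place of 3-fluorophenyl, on a saturated chain carbon two bonds along the chain from a saturated ring carbon, gives a 1.1-fold higher number from compound 2 to compound 3 (0.06 log units; within the scatter). Set against the phenyl group, 4-fluorobenzyl gives a 1.7-fold higher number from compound 1 to compound 3 (0.22 log units; within the scatter), so 3-fluorophenyl and 4-fluorophenyl cannot be told apart here, and this assay separates none of compound 1, compound 2 and compound 3. No supporting data bear on why the position of the fluorine leaves no visible mark on the number.

The compounds shown leave open whether a group other than fluorine on this ring, such as a methoxy group or a carboxylic acid, would move the number beyond the scatter. They also leave open whether an amine in place of the ring, or a longer chain carrying the 4-fluorophenyl, would do so.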